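Sulfonamide nitrogen series: compound 3 to compound 4

The source may report more compounds than this note shows. Statements on the series, on what has been measured and on what is new or still open speak of the compounds shown alone.

- compound 1 `CC(C)CN(c1ccc(C(C)(C)C)cc1)S(=O)(=O)c1ccc2c(c1)C(=O)CC(C1CCOCC1)O2`: 4.97
- compound 2 `CC(C)CN(c1ccccc1F)S(=O)(=O)c1ccc2c(c1)C(=O)CC(C1CCOCC1)O2`: 3.44
- compound 3 `CC(C)CN(Cc1ccccc1C(F)(F)F)S(=O)(=O)c1ccc2c(c1)C(=O)CC(C1CCOCC1)O2`: 4.32

In a physicochemical assay for lipophilicity, at pH 7.4 (a lower number here means a more polar compound, a higher number a more lipophilic compound), compound 3, at 4.32, stands second highest of the three, below compound 1 and above compound 2. The next compound, compound 4 `CC(C)CN(c1ccc(N(C)C)cc1)S(=O)(=O)c1ccc2c(c1)C(=O)CC(C1CCOCC1)O2`, has 4-(dimethylamino)phenyl in place of 2-(trifluoromethyl)benzyl on a sulfonamide nitrogen.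

Three measured steps at this nitrogen bear on the change: a number 1.53 log units lower from compound 1 to compound 2 (beyond the scatter), a number 0.65 log units lower from compound 1 to compound 3 (beyond the scatter) and a number 0.88 log units higher from compound 2 to compound 3 (beyond the scatter). The first is large, the other two modest, and all exchange groups at this same place. Among the measured compounds shown here, no measured compound carries 4-(dimethylamino)phenyl, so the two phenyl-bearing compounds give only loose bounds: compound 2 at 3.44 and compound 1 at 4.97. A fall of small to modest size in this assay is expected, within that span.

The expected change is a number 0.37 log units lower from compound 3 to compound 4 (beyond the scatter). For compound 4 the estimated value is 3.95, with an expected range of 3.4 to 4.5.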

Compound 4, distribution coefficient: 3.6
For compound 4 the middle estimate is 0.35 log units above the measured one; low and high end bracket the measured number.
By their numbers in this assay, from the lowest: compounds 2 and 4 (each within the scatter of the next); then compound 3; then compound 1.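

In this assay, exchanging only the substituent on an aromatic carbon of the phenyl group gives a large step (a number 1.37 log units lower from compound 1 to compound 4 (beyond the scatter)), so that single exchange alone spans much of the range seen at the sulfonamide nitrogen. Compound 4 and compound 2 cannot be told apart (a number 0.16 log units higher from compound 2 to compound 4 (within the scatter)), although 4-(dimethylamino)phenyl and 2-fluorophenyl differ in both the substituent and where it is printed in the group's name, and both compounds stand clearly apart from compound 3 (a number 0.72 log units lower from compound 3 to compound 4 (beyond the scatter)). Nothing on hand accounts for these differences.

Open, going by these compounds, is how a primary amine or a carboxylic acid on that same aromatic carbon would read against dimethylamino and tert-butyl. Also open, on these data alone, is whether a 4-(dimethylamino)benzyl group on the sulfonamide nitrogen would keep the gap seen here between the phenyl and benzyl compounds.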